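The source may report more compounds than this note shows. Statements on the series, on what has been measured and on what is new or still open speak of the compounds shown alone.

Among the compounds with values here, in an ADME assay on L6 cells (Rattus norvegicus) for cytotoxicity, read by resazurin assay, with a stated time of 72 h (on this read-out lower numbers stand for stronger inhibition and higher numbers for weaker inhibition), three compounds with a shared core have numbers so far. Compound 1 (`CN1CCN(CC(=O)N2CC3C(c4ccccc4)CC(N(C)C)(CC3c3ccccc3)C2)CC1`) gives 9250 nM, compound 2 (`CN(C)C12CC(c3ccccc3)C(CN(CCN3CCCCC3)C1)C(c1ccccc1)C2`) gives 2920 nM, and compound 3 (`CN1CCN(CCN2CC3C(c4ccccc4)CC(N(C)C)(CC3c3ccccc3)C2)CC1`) gives 5260 nM. Compound 3 stands within the scatter of both others, as a 1.8-fold lower number from compound 1 to compound 3 (0.25 log units; within the scatter) and a 1.8-fold higher number from compound 2 to compound 3 (0.26 log units; within the scatter) show. Within the data shown here, the only step beyond the scatter is a 3.2-fold lower number from compound 1 to compound 2 (0.50 log units; beyond the scatter), and it involves replacing a carbonyl-containing group, which is not at issue here.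

Compound 4 (`CN(C)C12CC(c3ccccc3)C(CN(CCCN3CCCC3)C1)C(c1ccccc1)C2`) differs from compound 3 as follows: (pyrrolidin-1-yl)methyl in place of 4-methylpiperazin-1-yl on a saturated chain carbon, two bonds along the chain from an amine nitrogen in a ring. Read one bond further out, 2-(4-methylpiperazin-1-yl)ethyl becomes 3-(pyrrolidin-1-yl)propyl. The closest guide is the exchange of the end ring alone, a 1.8-fold higher number from compound 2 to compound 3 (0.26 log units; within the scatter), a small step. Among the measured compounds shown here, no measured pair tests a change in chain length, so the estimate remains loose. The expected step is a 1.8-fold lower number from compound 3 to compound 4 (0.24 log units; within the scatter), which would be a small move towards a lower number in this assay, probably not beyond the scatter. For compound 4 the estimated value is 3000 nM, with an expected range from 1300 nM to 6500 nM.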

Compound 4, half-maximal inhibitory concentration: 1550 nM
The estimate for compound 4 lay 1.9-fold (0.29 log units) above the measured number; measured number inside the range.
By their numbers in this assay, from the lowest: compounds 4, 2, 3 and 1 (each within the scatter of the next, the first and the last beyond it).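

In this assay this change at the chain gives a 3.4-fold lower number from compound 3 to compound 4 (0.53 log units; beyond the scatter), a step beyond the scatter with no carbonyl-containing group involved, so the side chain alone can move the number once both the end ring and the chain are altered. Set against the piperidin-1-yl compound, the change gives only a 1.9-fold lower number from compound 2 to compound 4 (0.28 log units; within the scatter), so that pair cannot be told apart, while the full replacement gives a 6.0-fold lower number from compound 1 to compound 4 (0.78 log units; beyond the scatter), the largest step in this set. No evidence here accounts for these steps.

From the compounds shown here alone, compound 4 alters the end ring and the chain length together, so the share of each remains open. A 2-(pyrrolidin-1-yl)ethyl group would separate the two, and an open-chain amine such as diethylamino at the chain end would test whether an end ring is needed at all.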